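Swapping a urea tail for a thiophene ring

The compounds below may be only part of what the source reports. "The series", "measured", "known", "first", "only" and "open" are said of these compounds alone.

Compound 1 `CCNc1nc(C)c(-c2nc3ccccc3s2)c(N[C@@H]2C[C@H](CO)[C@@H](O)[C@H]2O)n1`, in an ADME assay on cells (Homo sapiens) for cytotoxicity, read by polymerase chain reaction, with a stated time of 3 days (on this read-out higher numbers stand for lower toxicity in this test and lower numbers for higher toxicity in this test), gives 12000 nM. Compound 2 `Cc1nc(NCCNC(=O)NC(C)(C)C)nc(N[C@@H]2C[C@H](CO)[C@@H](O)[C@H]2O)c1-c1nc2ccccc2s1` carries a longer side arm on the same core. In this assay, as far as these compounds go, compound 2 returns only a limit, > 25000 nM, so its true number is unknown. Among the measured compounds shown here, the measured step of an at least 2.0-fold higher number from compound 1 to compound 2 (0.31 log units; beyond the scatter) is the only comparison available, and compound 2 sits at the limit of > 25000 nM in this assay, at which 1 of the 2 values shown sits.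

Compound 3 `Cc1nc(NCc2ccsc2)nc(N[C@@H]2C[C@H](CO)[C@@H](O)[C@H]2O)c1-c1nc2ccccc2s1` differs from compound 2 by thiophen-3-yl in place of (((tert-butyl)carbamoyl)amino)methyl on a saturated chain carbon bound to a nitrogen on an aromatic ring. For the measured compounds named here, no measured step covers this exchange directly; the only related one, an at least 2.0-fold higher number from compound 1 to compound 2 (0.31 log units; beyond the scatter), shows that adding the urea-bearing piece moved the number upward beyond the scatter. Taking that piece away again and placing an aromatic ring in its stead could bring the number back toward that of compound 1, or leave it at the limit. For compound 3 the estimated result in this assay is 15000 nM, with a range of 5000 nM to 40000 nM, which would mean an expected step of an at least 1.6-fold lower number from compound 2 to compound 3 (0.22 log units; that floor lies within the scatter).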

Compound 3, half-maximal cytotoxic concentration: 6000 nM
Estimate against measurement, compound 3: 2.5-fold (0.40 log units) above; the measured number falls inside the stated range.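

In this assay, the arm on this nitrogen now shows that a bigger group alone does not give a higher number: thiophen-3-yl in place of (((tert-butyl)carbamoyl)amino)methyl gives an at least 4.1-fold lower number from compound 2 to compound 3 (0.61 log units; beyond the scatter). The other comparison gives a 2.0-fold lower number from compound 1 to compound 3 (0.30 log units; within the scatter), so the thiophene arm and the short chain of compound 1 cannot be told apart here, and among these three compounds only the urea-bearing arm stands out toward lower toxicity in this test. The step from compound 2 is only a floor, and its real size stays unknown because compound 2 has only a limit: the limit of > 25000 nM in this assay, at which 1 of the 3 values shown sits.

As far as these compounds go, it remains open whether the urea carbonyl or the tert-butyl group goes with the higher number. A simple amine or a carboxylic acid at the end of the same ethyl arm could help separate chain length from the urea itself.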